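The compounds below may be only part of what the source reports. "The series", "measured", "known", "first", "only" and "open" are said of these compounds alone.

Values in a functional assay on U-937 cells (Homo sapiens), read by cAMP accumulation; on this read-out higher numbers stand for an effect only at larger amounts of compound and lower numbers for an effect already at smaller amounts:
compound 1 `CCc1nn(-c2ccc(F)cc2)c2c1CCN(c1ccccc1)C2=O`: 880 nM
compound 2 `CCc1nn(C2CCCC2)c2c1CCN(c1ccccc1)C2=O`: 70 nM

Compound 2 holds the lower of the two numbers. Compound 3 `CCc1nn(C2CCCC2)c2c1CCN(c1cccc(OC)c1)C2=O` differs from compound 2 by methoxy in place of hydrogen on an aromatic carbon, with methoxy in place of hydrogen on an aromatic carbon. Among the measured compounds shown here, the only measured step, a 13-fold lower number from compound 1 to compound 2 (1.10 log units; beyond the scatter), was large, but it concerns a change on an aromatic nitrogen, so it offers no size for this change. Without a direct precedent, no clear direction can be assigned, and little change beyond the scatter is expected in this assay. The expected result is a 1.1-fold lower number from compound 2 to compound 3 (0.03 log units; within the scatter). Compound 3 is estimated at 65 nM, within a range of 18 nM to 240 nM.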

Compound 3, half-maximal effective concentration: 330 nM
The estimate for compound 3 lay 5.1-fold (0.71 log units) below the measured number, and the stated range ends below it.
By their numbers in this assay, from the lowest: compound 2; then compound 3; then compound 1.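

In this assay, the phenyl group on the shared core proves sensitive to substitution: 3-methoxyphenyl in place of phenyl gives a 4.7-fold higher number from compound 2 to compound 3 (0.67 log units; beyond the scatter), a modest step beyond the scatter. Among the compounds shown here, the earlier compounds differed only on an aromatic nitrogen, so this is the first sign that this part of the molecule also moves the number. Nothing available accounts for the step. As far as these compounds go, whether the rise belongs to methoxy itself or to any group at this place remains open. So does how a hydroxyl, a fluorine or an amine on this ring would compare.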